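Aryl replacement on the shared core: notes ahead of measurement

The source may report more compounds than this note shows. Statements on the series, on what has been measured and on what is new or still open speak of the compounds shown alone.

Three analogues of the shared core have numbers in an in vitro assay on HEK385-7 cells for displacement of a labelled ligand from prostaglandin D2 receptor 2 (Homo sapiens); on this read-out lower numbers stand for stronger inhibition and higher numbers for weaker inhibition. Compound 1 `N#Cc1cc(-c2nc(C(c3ccc(F)cc3)c3ccc(F)cc3)sc2CC(=O)O)ccc1F` gives 57 nM and sits second highest of the three. Compound 2 `O=C(O)Cc1sc(C(c2ccc(F)cc2)c2ccc(F)cc2)nc1-c1cc(F)cc(F)c1` gives 35 nM; the step of a 1.6-fold lower number from compound 1 to compound 2 (0.21 log units; within the scatter) keeps the two within the scatter. Compound 3 `O=C(O)Cc1sc(C(c2ccc(F)cc2)c2ccc(F)cc2)nc1-c1ccnc(N2CCCC2)c1` gives 230 nM, the furthest from compound 1, with a 4.0-fold higher number from compound 1 to compound 3 (0.61 log units; beyond the scatter); the related step of a 6.6-fold higher number from compound 2 to compound 3 (0.82 log units; beyond the scatter) is of similar size.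

Compound 4 `NS(=O)(=O)c1cccc(-c2nc(C(c3ccc(F)cc3)c3ccc(F)cc3)sc2CC(=O)O)c1` awaits measurement. Its difference from compound 1: 3-sulfamoylphenyl in place of 3-cyano-4-fluorophenyl on an aromatic carbon. Both measured steps change the same position. Exchange for 3,5-difluorophenyl gave a 1.6-fold lower number from compound 1 to compound 2 (0.21 log units; within the scatter), whereas exchange for 2-(pyrrolidin-1-yl)pyridin-4-yl gave a 4.0-fold higher number from compound 1 to compound 3 (0.61 log units; beyond the scatter). Nothing in the measured set carries a 3-sulfamoylphenyl or anything resembling it, so the direction rests on the pattern that a phenyl-for-phenyl swap stayed within scatter while the larger departure cost a modest amount. For compound 4 a modest rise in number, a 2.1-fold higher number from compound 1 to compound 4 (0.32 log units; beyond the scatter), is expected in this assay. Compound 4 is therefore estimated at 120 nM, with a range of 40 nM to 400 nM.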

Compound 4, half-maximal inhibitory concentration: 140 nM
Compound 4: the middle estimate sits 1.2-fold (0.07 log units) below what was measured; low and high end bracket the measured number.
By their numbers in this assay, from the lowest: compounds 2 and 1 (each within the scatter of the next); then compounds 4 and 3 (each within the scatter of the next).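

In this assay the 3-sulfamoylphenyl group keeps a six-membered aromatic ring of carbon only, yet the exchange gives a 2.5-fold higher number from compound 1 to compound 4 (0.39 log units; beyond the scatter) and, against the other phenyl analogue, a 4.0-fold higher number from compound 2 to compound 4 (0.60 log units; beyond the scatter), so keeping that ring at this position does not by itself hold the number within the scatter. The comparison with the pyridine analogue gives a 1.6-fold lower number from compound 3 to compound 4 (0.22 log units; within the scatter), so 3-sulfamoylphenyl and 2-(pyrrolidin-1-yl)pyridin-4-yl cannot be told apart here despite their different rings. No measured evidence on this series accounts for these steps.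

Open, as far as these compounds go, is whether the sulfamoyl group itself sets the step: a methylsulfonyl group or a primary amide on the same phenyl ring would test this. Also open, from the compounds shown here alone, is whether either replacement would stay with compound 4 or return towards compound 1.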